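The compounds below may be only part of what the source reports. "The series", "measured", "known", "first", "only" and "open" are said of these compounds alone.

Measured so far:
compound 1 `COc1ccc(-c2cccc(=O)n2-c2cc(OC)c(OC)c(OC)c2)cc1OCc1ccccc1` — 2310 nM
compound 2 `COc1ccc(-c2cccc(=O)n2-c2cc(OC)c(OC)c(OC)c2)cc1OC` — 545 nM

In a functional assay on SK-OV-3 cells (Homo sapiens) for cytotoxicity, read by spectrophotometry, with a stated time of 72 h (on this read-out lower numbers stand for stronger inhibition and higher numbers for weaker inhibition), compound 1 gives 2310 nM, the highest of the two numbers recorded, while compound 2 gives 545 nM. Among the compounds with values here, the only step recorded between them, a 4.2-fold lower number from compound 1 to compound 2 (0.63 log units; beyond the scatter), replaces the benzyloxy of compound 1 with a methoxy and lowers the number beyond the scatter.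

Compound 3 `COc1ccc(-c2cccc(=O)n2-c2cc(OC)c(OC)c(OC)c2)cc1C` has not yet been measured. It differs from compound 1 in one place: methyl in place of benzyloxy on an aromatic carbon. Like compound 2, compound 3 therefore loses the benzyloxy on an aromatic carbon that sits ortho to a methoxy group and meta to a large group, but here a methyl enters instead of a methoxy.

The step from compound 1 to compound 2 is the only one that bears on this change, and it was modest and downward. The account therefore expects the number for compound 3 to fall below that of compound 1 by a comparable modest amount, a 3.3-fold lower number from compound 1 to compound 3 (0.52 log units; beyond the scatter), because compound 2 already showed a 4.2-fold lower number from compound 1 to compound 2 (0.63 log units; beyond the scatter) on removing the benzyloxy. With the methyl untested here, the expected value for compound 3 is 700 nM, within a range of 250 nM to 2000 nM.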

Compound 3, half-maximal inhibitory concentration: 583 nM
Compound 3: the middle estimate sits 1.2-fold (0.08 log units) above what was measured, and the stated range covers the measured number.
By their numbers in this assay, from the lowest: compounds 2 and 3 (each within the scatter of the next); then compound 1.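

In this assay, losing the benzyloxy again goes with a lower number (a 4.0-fold lower number from compound 1 to compound 3 (0.60 log units; beyond the scatter)), this time with a methyl entering on the aromatic carbon rather than a methoxy. Methyl and methoxy at this place cannot be told apart (a 1.1-fold higher number from compound 2 to compound 3 (0.03 log units; within the scatter)), so the earlier drop does not depend on methoxy as the entering group, and among these three compounds the two small groups stand together while the benzyloxy of compound 1 stands apart, with no compound going against this. Nothing measured here explains why compound 1 gives the higher number.

From the compounds shown here alone, it remains open whether a hydroxyl, a chlorine or an amine on this aromatic carbon would join methyl and methoxy, and whether a longer chain such as propoxy or butoxy would give a number nearer to that of the methyl or the benzyloxy compound. Going by these compounds, it is also open whether a phenethoxy, or a benzyloxy carrying a fluorine on its ring, would behave as the benzyloxy of compound 1 does in this assay.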